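A Ring-Closed Tail Replaces a Protected Chain

The compounds below may be only part of what the source reports. "The series", "measured", "known", "first", "only" and "open" are said of these compounds alone.

Of the compounds shown here, three built on one shared core have been measured so far. Compound 1 `CC(C)(C)OC(=O)NCCCNC(=O)CN1CN(c2ccccc2)C2(CCN(C(=O)c3ccc(C4CCCCC4)cc3)CC2)C1=O` gives 6000 nM in an assay on HEK293 cells for displacement of a labelled ligand from NPC1-like intracellular cholesterol transporter 1 (Homo sapiens); a lower number here means a stronger inhibitor, a higher number a weaker inhibitor. Compound 2 `CC(C)(C)OC(=O)NCCCNC(=O)CN1CN(c2ccccc2)C2(CCN(C(=O)c3ccc(C(C)(C)C)cc3)CC2)C1=O` gives 4500 nM in this assay, and compound 3 `CC(C)(C)OC(=O)NCCCCNC(=O)CN1CN(c2ccccc2)C2(CCN(C(=O)c3ccc(C4CCCCC4)cc3)CC2)C1=O` gives 4600 nM. Compound 1 stands within the usual scatter of both neighbours: the change of tert-butyl in place of cyclohexyl on an aromatic carbon gives a 1.3-fold lower number from compound 1 to compound 2 (0.12 log units; within the scatter), and the lengthening of the chain by one carbon gives a 1.3-fold lower number from compound 1 to compound 3 (0.12 log units; within the scatter).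

Compound 4 `NC(=O)C1CCCN(C(=O)CN2CN(c3ccccc3)C3(CCN(C(=O)c4ccc(C5CCCCC5)cc4)CC3)C2=O)C1` has not yet been measured. It differs from compound 1 at the tail amide: 3-carbamoylpiperidin-1-yl in place of (3-((tert-butoxycarbonyl)amino)propyl)amino on a carbonyl carbon. The open chain carrying the protected amine is thus replaced by a six-membered ring carrying a carboxamide.

Neither measured step touches this part of the molecule; both sit elsewhere and both stayed within the scatter. There is therefore no direct guide for the size of this step, and the two steps seen so far suggest that this core tolerates small changes without much movement in the numbers. A step of a 1.2-fold lower number from compound 1 to compound 4 (0.08 log units; within the scatter) is expected, meaning little change beyond the scatter. Compound 4 is estimated at 5000 nM, within a range of 1500 nM to 15000 nM.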

Compound 4, half-maximal inhibitory concentration: 3100 nM
Estimate against measurement, compound 4: 1.6-fold (0.21 log units) above; measured number inside the range.
By their numbers in this assay, from the lowest: compounds 4, 2, 3 and 1 (each within the scatter of the next).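

Replacing the open chain (3-((tert-butoxycarbonyl)amino)propyl)amino on this carbonyl carbon with 3-carbamoylpiperidin-1-yl, which brings in one six-membered non-aromatic ring, gives in this assay a step of a 1.9-fold lower number from compound 1 to compound 4 (0.29 log units; within the scatter). Among the compounds shown here, this is the first look at the tail itself, and it shows that in this pair the tert-butoxycarbonyl group and the open chain can both be lost without the number leaving the scatter, even though the change replaces the whole group at this position rather than a small part of it. Going by these compounds, no other measurement bears on this result, so what the ring and the carboxamide each contribute remains unknown.

Compound 4 differs from compound 1 in both the shape of the tail and its end group, and the compounds shown cannot separate these two changes. A plain piperidine without the carboxamide, a free primary amine at the end of the propyl chain, or a carboxylic acid in place of the carboxamide would test whether any change at this position can move the number beyond the scatter.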